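The source may report more compounds than this note shows. Statements on the series, on what has been measured and on what is new or still open speak of the compounds shown alone.

Working notes on the series. Of the compounds shown here, two have been measured so far, both at similar levels in a functional assay on KB cells (Homo sapiens) for inhibition; a higher number here means a weaker inhibitor, a lower number a stronger inhibitor. In this read-out, compound 1 `COC[C@H]1O[C@@H](n2c(Cl)nc3cc(Cl)c(Cl)cc32)[C@H](OC(C)=O)[C@@H]1OC(C)=O` gives 80000 nM. Compound 2 `CCCCOC[C@H]1OC(n2c(Cl)nc3cc(Cl)c(Cl)cc32)[C@H](O)[C@@H]1O` gives 60000 nM. Compound 2 therefore stands within the scatter of compound 1, and the two values cannot be ranked.

The next compound is compound 3 `O[C@@H]1[C@@H](CBr)OC(n2c(Cl)nc3cc(Cl)c(Cl)cc32)[C@@H]1O`, which has not yet been measured. It departs from compound 2 at one place, on a saturated chain carbon bound to a saturated ring carbon, where bromo stands in place of butoxy: bromo in place of butoxy on a saturated chain carbon bound to a saturated ring carbon. Read one bond further out, this is butoxymethyl to bromomethyl.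

Within the data shown here, no measured compound here carries bromo, and no measured step shows what this exchange does, so the basis for a forecast is thin. Among the measured compounds shown here, the only guide is the level set by compound 1 at 80000 nM and compound 2 at 60000 nM. The expected change is a 1.2-fold lower number from compound 2 to compound 3 (0.08 log units; within the scatter), which is no step beyond the scatter in either direction. In this assay, compound 3 is estimated at 50000 nM, with an expected range of 15000 nM to 120000 nM.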

Compound 3, half-maximal inhibitory concentration: 90000 nM
For compound 3 the middle estimate is 1.8-fold (0.26 log units) below the measured one; the measured number falls inside the stated range.
By their numbers in this assay, from the lowest: compounds 2, 1 and 3 (each within the scatter of the next).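

In this assay the exchange of butoxy for bromo gives a 1.5-fold higher number from compound 2 to compound 3 (0.18 log units; within the scatter) at this position, on a saturated chain carbon bound to a saturated ring carbon. Among these compounds, this is the first step that can be read at this place, and it shows that butoxymethyl and bromomethyl cannot be told apart in this read-out. The butoxy chain with its oxygen is therefore not needed to hold the level seen in compound 2, since a lone bromine in its place gives a value within the scatter. No evidence on hand bears on this result.

Still open, from the compounds shown here alone, is whether any group at this place can move the number beyond the scatter, and an amine, a carboxylic acid or a longer chain on this carbon would test that. Among the compounds shown here, also open is what the acetate esters of compound 1 contribute, as that compound differs from compound 2 in more than one place and the pair gives no step that can be read.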